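Swapping 1-chloroethenyl for pent-1-en-1-yl on compound 3

This account rests on a few compounds, and the source may have more. Where it says the series, first, only, none or still open, it means among the compounds named here.

Measured so far in a functional assay on A549 cells (Homo sapiens) for inhibition, read by MTT assay, with a stated time of 72 h; a lower number here means a stronger inhibitor, a higher number a weaker inhibitor
- compound 1 (`CC/C=C\C(=O)Nc1cc(Nc2nc3c(c(-c4cn(C)c5ccc(F)cc45)n2)CSCC3)c(OC)cc1N(C)CCN(C)C`) gives 1450 nM
- compound 2 (`CCC/C=C\C(=O)Nc1cc(Nc2nc3c(c(-c4cn(C)c5ccc(F)cc45)n2)CSCC3)c(OC)cc1N(C)CCN(C)C`) gives 5190 nM
- compound 3 (`C=C(Cl)C(=O)Nc1cc(Nc2nc3c(c(-c4cn(C)c5ccccc45)n2)CS(=O)(=O)CC3)c(OC)cc1N(C)CCN(C)C`) gives 881 nM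

Compound 3 at 881 nM lies within the scatter of compound 1 and well under the value of compound 2 in this small set. Compound 4 (`CCC/C=C\C(=O)Nc1cc(Nc2nc3c(c(-c4cn(C)c5ccccc45)n2)CS(=O)(=O)CC3)c(OC)cc1N(C)CCN(C)C`) keeps the core of compound 3 and changes only the amide end: pent-1-en-1-yl in place of 1-chloroethenyl on a carbonyl carbon.

Going by the values given here, only one measured step bears on this, and only indirectly. The chain extension shows a 3.6-fold higher number from compound 1 to compound 2 (0.55 log units; beyond the scatter), a modest step beyond the scatter, on a core other than that of compound 3. Compound 2 carries the same pent-1-en-1-yl group and reads 5190 nM on that other core. No measurement compares 1-chloroethenyl with pent-1-en-1-yl directly on one core.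

A higher number in this assay is therefore expected, of similar or somewhat larger size than that step. The expected step is a 4.0-fold higher number from compound 3 to compound 4 (0.60 log units; beyond the scatter), an estimate resting on thin evidence. For compound 4 the estimated value is 3500 nM, with 1300 nM to 9000 nM as the expected range.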

Compound 4, half-maximal inhibitory concentration: 57 nM
Compound 4: middle estimate off by 61-fold (1.79 log units), on the high side, and the stated range ends above it.
By their numbers in this assay, from the lowest: compound 4; then compounds 3 and 1 (each within the scatter of the next); then compound 2.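

In this assay, the group on the carbonyl carbon proves to be a strong lever on the core of compound 3: pent-1-en-1-yl in place of 1-chloroethenyl gives a 15-fold lower number from compound 3 to compound 4 (1.19 log units; beyond the scatter). Going by these compounds alone, its direction is opposite to that of the only earlier step at the amide end, a 3.6-fold higher number from compound 1 to compound 2 (0.55 log units; beyond the scatter), which is a different change on a different core and so gives no reliable guide to this exchange. Nothing measured here accounts for the size of the new step.

Because the exchange removes the chlorine and alters the chain in a single move, the two pairs shown cannot separate those contributions, and it remains open whether a plain ethenyl group, a but-1-en-1-yl group or a longer chain such as hex-1-en-1-yl on the core of compound 3 would read closer to compound 3 or to compound 4. Also open, from the compounds shown here alone, is whether 1-chloroethenyl and pent-1-en-1-yl would differ to the same extent on the core of compound 1, where the ring carries fluorine and the sulfur is not oxidised.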